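A Single Fluorine Added to the Outer Phenyl of Compound 3

The source may report more compounds than this note shows. Statements on the series, on what has been measured and on what is new or still open speak of the compounds shown alone.

Of the compounds shown here, three sharing one core have been tested in a functional assay on A549 cells (Homo sapiens) for cytotoxicity, read by MTT assay, with a stated time of 72 h; on this read-out lower numbers stand for stronger inhibition and higher numbers for weaker inhibition. Compound 1 `Cc1ccc(-c2ccnc(C(=O)Nc3ccc(Oc4ccnc5[nH]ccc45)cc3)c2)cc1` is the one case where the assay reports only a limit rather than a number: in this assay compound 1 gives > 10000 nM. Among the compounds with values here, compound 2 `O=C(Nc1ccc(Oc2ccnc3[nH]ccc23)cc1)c1cc(-c2ccccc2)ccn1` carries a hydrogen where compound 1 carries a methyl; in this assay compound 2 gives 2920 nM, and the step of an at least 3.4-fold lower number from compound 1 to compound 2 (0.53 log units; beyond the scatter) is the only single change measured on both sides. Compound 3 `O=C(Nc1ccc(Oc2ccnc3[nH]ccc23)c(F)c1)c1ccc(-c2ccccc2)cn1` differs from compound 2 at two places, and in this assay compound 3 gives 1250 nM, the lowest of the two numbers, with compound 2 standing beyond the scatter above it.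

Compound 4 `O=C(Nc1ccc(Oc2ccnc3[nH]ccc23)c(F)c1)c1ccc(-c2ccc(F)cc2)cn1` differs from compound 3 by fluoro in place of hydrogen on an aromatic carbon, on an aromatic carbon of a six-membered aromatic ring of carbon only, para to a large group; read one bond further out, phenyl becomes 4-fluorophenyl. Within the data shown here, the one measured step at this position runs the other way, from methyl to hydrogen, and is an at least 3.4-fold lower number from compound 1 to compound 2 (0.53 log units; beyond the scatter), so adding a group there raised the number. Fluoro enters as a single heavy atom, smaller than methyl, so a much smaller rise is expected, likely within the scatter. Compound 4 is therefore estimated at 1600 nM, ranging from 600 nM to 4500 nM. The expected step of a 1.3-fold higher number from compound 3 to compound 4 (0.11 log units; within the scatter) is modest.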

Compound 4, half-maximal inhibitory concentration: 6010 nM
Compound 4: the middle estimate sits 3.8-fold (0.57 log units) below what was measured, outside the stated range (above it).
By their numbers in this assay, from the lowest: compound 3; then compound 2; then compound 4. At a limit, above all of these: compound 1.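

In this assay, the hydrogen on the outer phenyl, para to a large group, turns out not to be a freely replaceable spot: 4-fluorophenyl in place of phenyl gives a 4.8-fold higher number from compound 3 to compound 4 (0.68 log units; beyond the scatter), so a change of 1 heavy atom is enough to move the number beyond the scatter. The earlier methyl-to-hydrogen step, an at least 3.4-fold lower number from compound 1 to compound 2 (0.53 log units; beyond the scatter), belongs to a pair that differs from compound 3 and compound 4 elsewhere in the molecule, yet the direction matches, since in both pairs the compound with hydrogen on the outer phenyl has the lower number and neither pair goes against this. Within the data shown here, compound 1 remains the only compound reported as a limit rather than a number: the limit of > 10000 nM in this assay, at which 1 of the 4 values shown sits.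

These two pairs cannot show why a group at this place raises the number, or whether any group would do so. On these data alone, it stays open whether a hydroxyl, an amine or a carboxylic acid at the same carbon would follow fluoro and methyl, or would instead bring the number down below that of compound 3.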